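A few compounds are considered here, and "the series" means these few. Any claim that something is new, unique, unknown or untested is made for them only; others in the source may bear on it.

For the measured compounds named here, compound 2 `O=C(/C=C/c1ccccc1Br)NNC(=O)c1ccc2c(c1)OCCO2` is one of two compounds measured in an ADME assay on cells (Macrophage) for cytotoxicity, read by MTT assay, with a stated time of 24 h; a higher number here means that more compound is tolerated, a lower number that less compound is tolerated. In this assay compound 2 gives 315000 nM, while compound 1 `Cc1ccccc1/C=C/C(=O)NNC(=O)c1ccc2c(c1)OCCO2` gives 268000 nM, the two numbers lying within the scatter of each other. Going by the values given here, the only measured step, a 1.2-fold higher number from compound 1 to compound 2 (0.07 log units; within the scatter), concerns a different exchange. Compound 3 `O=C(/C=C/c1ccccc1[N+](=O)[O-])NNC(=O)c1ccc2c(c1)OCCO2` differs from compound 2 by nitro in place of bromo on an aromatic carbon. Among the compounds with values here, no measured step tests this particular exchange, and the one step available barely moved the number. The step expected from this change is a 1.1-fold lower number from compound 2 to compound 3 (0.02 log units; within the scatter), none beyond the scatter. Compound 3 is therefore estimated at 300000 nM, with a range from 150000 nM to 600000 nM.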

Compound 3, half-maximal cytotoxic concentration: 257000 nM
Beside the measured number, compound 3's estimate is 1.2-fold (0.07 log units) above it; measured number inside the range.
By their numbers in this assay, from the lowest: compounds 3, 1 and 2 (each within the scatter of the next).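

In this assay, placing nitro on this aromatic carbon, ortho to a large group, gives a 1.2-fold lower number from compound 2 to compound 3 (0.09 log units; within the scatter), and the exchange with methyl gives a 1.0-fold lower number from compound 1 to compound 3 (0.02 log units; within the scatter). Methyl, bromo and nitro at this position therefore all give numbers within the scatter of each other, and nitro, which unlike bromo carries hydrogen-bond acceptors, does not separate from them. Nothing measured alongside these compounds offers an explanation. Going by these compounds, whether an amine or a carboxylic acid here would move the number remains open, as does whether these three groups would also match at another carbon of the ring.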